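The compounds below may be only part of what the source reports. "The series", "measured", "known", "first", "only" and "open" are said of these compounds alone.

Measured in a functional assay on SNU-475 cells (Homo sapiens) for inhibition, read by sulforhodamine B assay, with a stated time of 72 h; on this read-out lower numbers stand for stronger inhibition and higher numbers for weaker inhibition:
Compound 1 `COc1cc(OC)c(C(=O)/C=C/c2cn(-c3ccccc3)nc2-c2cccnc2)c(OC)c1` gives 800 nM.
Compound 2 `COc1ccc(OC)c(C(=O)/C=C/c2cn(-c3ccccc3)nc2-c2cccnc2)c1` gives 1900 nM.

Compound 2 carries the higher of the two numbers; its nearest neighbour is compound 1, whose number is lower by a margin beyond the usual scatter. Compound 3 `COc1ccc(OC)c(C(=O)/C=C/c2cn(-c3ccccc3)nc2-c2ccncc2)c1` differs from compound 2 in one place: pyridin-4-yl in place of pyridin-3-yl on an aromatic carbon. For the measured compounds named here, no measured pair shows this change, so there is nothing to size it from. In this assay the expected step is small, in either direction, and probably not beyond the scatter: a 1.1-fold higher number from compound 2 to compound 3 (0.02 log units; within the scatter). Compound 3 is therefore estimated at 2000 nM, within a range from 700 nM to 6000 nM.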

Compound 3, half-maximal inhibitory concentration: 2000 nM
Beside the measured number, compound 3's estimate shows no gap at the digits printed; the measured number falls inside the stated range.
By their numbers in this assay, from the lowest: compound 1; then compounds 2 and 3 (each within the scatter of the next).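

In this assay, for the compounds shown here, placing pyridin-4-yl in place of pyridin-3-yl on this aromatic carbon gives a 1.1-fold higher number from compound 2 to compound 3 (0.02 log units; within the scatter), the first sized change at this position, where the earlier compounds carried only pyridin-3-yl. For this pair, the two pyridine attachments cannot be told apart by this read-out. No available evidence accounts for this result.

What the compounds shown leave open is whether pyridin-2-yl, plain phenyl or an aminophenyl group at this carbon would read the same. As far as these compounds go, it is also open whether the same exchange would give a similar step on the core of compound 1.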